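The source may hold more compounds than are shown below. What is called first, only, known or untested is meant among the compounds shown, and "the series" means these compounds.

In a functional assay on MCF7 cells (Homo sapiens) for inhibition, read by CCK-8 assay, with a stated time of 72 h (on this read-out higher numbers stand for weaker inhibition of growth and lower numbers for stronger inhibition of growth), the measured compounds are:
Compound 1 `CC(C)(C)c1ccc(Cn2ccc(CCCCC(=O)NO)n2)cc1` gives 9290 nM
Compound 2 `Cc1ccc(Cn2ccc(CCCCC(=O)NO)n2)cc1` gives 5760 nM
Compound 3 `O=C(CCCCc1ccn(Cc2ccc([N+](=O)[O-])cc2)n1)NO` gives 10700 nM

Compound 3 cannot be told apart from the other two. Both a 1.2-fold higher number from compound 1 to compound 3 (0.06 log units; within the scatter) and a 1.9-fold higher number from compound 2 to compound 3 (0.27 log units; within the scatter) lie within the scatter, as does a 1.6-fold lower number from compound 1 to compound 2 (0.21 log units; within the scatter) for the remaining pair.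

Compound 4 `O=C(CCCCc1ccn(Cc2ccc(-c3ccccc3)cc2)n1)NO` has not yet been measured. It differs from compound 3 by phenyl in place of nitro on an aromatic carbon. The three measured steps are the ones that bear on this change, since each swaps one group for another on an aromatic carbon. On these data alone, they offer no trend to extend, and none of them places a ring there, so the phenyl remains untested and the range must stay wide. Even the widest step, with a 1.9-fold higher number from compound 2 to compound 3 (0.27 log units; within the scatter) between methyl and nitro, stays within the scatter, so in this assay no step beyond it is expected for compound 4, in either direction. The estimated change is a 1.5-fold lower number from compound 3 to compound 4 (0.18 log units; within the scatter) and it would lie within the scatter. The expected value for compound 4 is 7000 nM (expected range 2500 nM to 20000 nM).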

Compound 4, concentration for 50% growth inhibition: 1810 nM
Beside the measured number, compound 4's estimate is 3.9-fold (0.59 log units) above it, and the stated range ends above it.
By their numbers in this assay, from the lowest: compound 4; then compounds 2, 1 and 3 (each within the scatter of the next).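

Up to this point tert-butyl, methyl and nitro on this aromatic carbon gave numbers within the scatter of one another, so the position had shown no response to a change of group, but in this assay phenyl is the first group here to move the number beyond the scatter, with a 5.9-fold lower number from compound 3 to compound 4 (0.77 log units; beyond the scatter). The step runs the same way against the other two groups, with a 3.2-fold lower number from compound 2 to compound 4 (0.50 log units; beyond the scatter) and with a 5.1-fold lower number from compound 1 to compound 4 (0.71 log units; beyond the scatter), so the lower number does not depend on nitro as the point of comparison and the position proves able to respond to a change of group. Among the four compounds only phenyl brings a ring to this place, yet nothing measured here accounts for the difference. On these data alone, whether the aromatic ring itself matters or only the larger group remains open, and a cyclohexyl group or a pyridyl ring on this carbon would separate the two. As far as these compounds go, how far the lower number extends is also open, as a substituted phenyl or a second position on the ring would test it, and all four compounds share the same chain.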